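The compounds below may be only part of what the source reports. "The series", "measured", "known", "first", "only" and "open" are said of these compounds alone.

Of the compounds shown here, three have been measured in a functional assay on HepG2 cells (Homo sapiens) for inhibition, read by MTT assay, with a stated time of 72 h (on this read-out lower numbers stand for stronger inhibition and higher numbers for weaker inhibition), and a fourth awaits measurement. Compound 1, `Cc1nc(N(C)C(=O)NC(=O)c2c(F)cccc2F)sc1C(=O)N/N=C/c1cccc(C(F)(F)F)c1`, gives 31.6 ug/mL in this assay. Compound 2, `CN(C(=O)NC(=O)c1ccc(C(F)(F)F)cc1)c1nc(C(F)(F)F)c(C(=O)N/N=C/c2cccc(C(F)(F)F)c2)s1`, gives 7.95 ug/mL, and compound 3, `CN(C(=O)NC(=O)c1ccc(C(F)(F)F)cc1)c1nc(C(F)(F)F)c(C(=O)N/N=C/c2cc(C(F)(F)F)cc(C(F)(F)F)c2)s1`, gives 8.35 ug/mL. Compound 1 thus carries the highest number of the three; its nearest neighbour is compound 3, and both compound 2 and compound 3 sit beyond the usual scatter from it. How the core of compound 1 differs from the core of compound 2 is not broken down here.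

Compound 3 arises from compound 2 by a single change: trifluoromethyl in place of hydrogen on an aromatic carbon That change produced a 1.1-fold higher number from compound 2 to compound 3 (0.02 log units; within the scatter), so in this pair it left the number essentially unchanged.

Compound 4, `Cc1nc(N(C)C(=O)NC(=O)c2c(F)cccc2F)sc1C(=O)N/N=C/c1cc(C(F)(F)F)cc(C(F)(F)F)c1`, has not yet been measured. It arises from compound 1 by the same change: trifluoromethyl in place of hydrogen on an aromatic carbon The surroundings of the place are the same in both pairs, each time on an aromatic carbon of a six-membered aromatic ring of carbon only, meta to a large group and meta to a trifluoromethyl group. The step from compound 1 to compound 4 is expected to be a 1.0-fold higher number from compound 1 to compound 4 (0.02 log units; within the scatter), because the same change earlier gave a 1.1-fold higher number from compound 2 to compound 3 (0.02 log units; within the scatter) and stayed within the scatter. Compound 4 is therefore estimated at 33 ug/mL in this assay. Its likely span is expected to run from 15 ug/mL to 70 ug/mL.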

Compound 4, half-maximal inhibitory concentration: 11.4 ug/mL
The estimate for compound 4 lay 2.9-fold (0.46 log units) above the measured number, and the stated range ends above it.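

In this assay, the measured step is a 2.8-fold lower number from compound 1 to compound 4 (0.44 log units; beyond the scatter), so on the core of compound 1, trifluoromethyl in place of hydrogen on an aromatic carbon moved the number towards stronger inhibition. Set beside the earlier pair, the change did not carry over in size from one core to the other, even though the surroundings of the place are the same in both pairs: the same change on two cores in this assay, a 1.1-fold higher number (0.02 log units; within the scatter) from compound 2 to compound 3 and a 2.8-fold lower number (0.44 log units; beyond the scatter) from compound 1 to compound 4, 2.9-fold (0.46 log units) apart, beyond the scatter of two such steps This shows that, in this series, the size of the step cannot simply be transferred between these two cores, but it does not show which part of the cores is responsible, as they differ in more than one place, and two pairs give no rule for any further core.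

The compounds shown carry only hydrogen or trifluoromethyl at this place, so it remains open what a chlorine, a methoxy group or a nitrile there would do on either core. As far as these compounds go, it also remains open how the same change would behave on a core combining parts of the core of compound 1 with parts of the core of compound 2, which could show which part governs the size of the step.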